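The source may hold more compounds than are shown below. What is called first, only, known or untested is meant among the compounds shown, and "the series" means these compounds.

The measured compounds and their values:
compound 1 `CCCC(=O)OCSc1ccccc1C(=O)NCC(N)=O`: > 100 uM
compound 2 `CCCC(=O)OCSc1ccccc1C(=O)NCCCCCC(N)=O`: 16.3 uM
compound 3 `CCCC(=O)OCSc1ccccc1C(=O)Nc1ccc(C(N)=O)cc1`: 39 uM

In an ADME assay on CEM-SS cells (Homo sapiens) for cytotoxicity, read by XTT assay, with a stated time of 6 days (a lower number here means that less compound is tolerated, a higher number that more compound is tolerated), compound 2 gives 16.3 uM, the lowest of the two numbers shown. Compound 3 gives 39 uM, a higher number beyond the scatter. Compound 1 reaches only the limit > 100 uM, a limit rather than a number, (the limit of > 100 uM in this assay, at which 1 of the 3 values shown sits).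

Compound 4 `CCCC(=O)OCSc1ccccc1C(=O)NCC(=O)NC` differs from compound 2 by methylcarbamoyl in place of 4-carbamoylbutyl on a saturated chain carbon bound to an amide-type nitrogen. For the measured compounds named here, the one measured step that bears on this is an at least 6.1-fold lower number from compound 1 to compound 2 (0.78 log units; beyond the scatter), where lengthening the chain lowered the number. Compound 4 shortens it again part of the way, so a higher number is expected, a 3.7-fold higher number from compound 2 to compound 4 (0.57 log units; beyond the scatter). For compound 4 the estimate is 60 uM, with a range from 25 uM to 150 uM.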

Compound 4, half-maximal toxic concentration: > 100 uM
Compound 4: no number, only a limit; the forecaster's own chance of this, stated with the estimate: 30%; middle value at least 1.6-fold (0.22 log units) from the limit.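

In this assay, methylcarbamoyl in place of 4-carbamoylbutyl on a saturated chain carbon bound to an amide-type nitrogen gives an at least 6.1-fold higher number from compound 2 to compound 4 (0.78 log units; beyond the scatter), so the methyl on the short chain does not bring back the low number of compound 2. Compound 4 gives a limit rather than a number, and compound 1 sits at the same limit, so the step from compound 1 to compound 4 cannot be read: the limit of > 100 uM in this assay, at which 2 of the 4 values shown sit.

The compounds shown leave open where along a chain of intermediate length the number starts to fall. They also leave open whether an amine or a carboxylic acid in place of the carbamoyl on the longer chain would give a similar number.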